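This account rests on a few compounds, and the source may have more. Where it says the series, first, only, none or still open, it means among the compounds named here.

Measured in an ADME assay on MT4 cells (Homo sapiens) for cytotoxicity, read by MTT assay, with a stated time of 96 h; on this read-out higher numbers stand for lower toxicity in this test and lower numbers for higher toxicity in this test:

- Compound 1 `COc1ccc(-c2nc3cc(C(F)(F)F)ccc3[nH]2)c(OC)c1OC` gives 93000 nM.
- Compound 2 `COc1ccc(-c2nc3cc([N+](=O)[O-])ccc3[nH]2)c(OC)c1OC` gives > 100000 nM, which is a limit and not a number.
- Compound 3 `COc1ccc(-c2nc3cc(C(C)=O)ccc3[nH]2)c(OC)c1` gives > 100000 nM, which is also a limit and not a number.

Compound 3 therefore has no exact value and stands at the limit of > 100000 nM in this assay, at which 2 of the 3 values shown sit. Compound 4 `COc1ccc(-c2nc3cc(C(C)=O)ccc3[nH]2)c(OC)c1OC` differs from it by methoxy in place of hydrogen on an aromatic carbon, ortho to two methoxy groups and meta to a large group: methoxy in place of hydrogen on an aromatic carbon.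

Going by the values given here, no measured step makes this exchange. Among the compounds with values here, the only measured step, an at least 1.0-fold higher number from compound 1 to compound 2 (0.03 log units; that floor lies within the scatter), replaces trifluoromethyl with nitro, so it bears on the change only indirectly. The methoxy group that compound 4 gains is already carried by compound 1, which gives 93000 nM. Compound 2 also carries that methoxy group, and its > 100000 nM is a limit. On this evidence, no step beyond the scatter is expected in this assay, in either direction, and a further reading at the limit is the likeliest outcome. The expected change is a number no higher from compound 3 to compound 4 (the limit leaves the size open). For compound 4 the estimated value is 100000 nM, with an expected range from 60000 nM to 170000 nM.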

Compound 4, half-maximal cytotoxic concentration: > 100000 nM
Compound 4: a limit, no number; the forecaster's own chance of this, stated with the estimate: 75%; the middle value sits exactly at the limit.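

In this assay compound 4 gives > 100000 nM, which is a limit and not a number. Methoxy at this place, ortho to two methoxy groups and meta to a large group, thus leaves the reading at the limit with acetyl on the other side of the core, a pairing that the earlier compounds did not show, since compound 1 and compound 2 carry this methoxy group with trifluoromethyl and nitro instead. Acetyl in place of trifluoromethyl gives an at least 1.0-fold higher number from compound 1 to compound 4 (0.03 log units; that floor lies within the scatter), while the steps to compound 4 from compound 3 and from compound 2 cannot be read, and the series stays at a single limit: the limit of > 100000 nM in this assay, at which 3 of the 4 values shown sit.

As far as these compounds go, how far the methoxy exchange itself moves the reading stays open, as neither compound 3 nor compound 4 has a number. Also open, from the compounds shown here alone, is whether an amine or a carboxylic acid in place of the acetyl, or a longer chain in place of this methoxy, would give a reading under the limit and so a value that could be compared.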